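The compounds below may be only part of what the source reports. "The series", "measured", "known", "first", "only" and "open" are said of these compounds alone.

Working notes on a short series of three measured analogues and one pending compound.

Compound 1 `ClCc1ccc(Cn2cnc3c(Cl)ncnc32)cc1` is the reference point: in a functional assay on SF-539 cells (Homo sapiens) for cytotoxicity, read by sulforhodamine B assay, with a stated time of 48 h (a higher number here means a weaker inhibitor of growth, a lower number a stronger inhibitor of growth), compound 1 gives 1170 nM. Compound 2 `Nc1nc(Cl)c2ncn(Cc3ccc(CCl)cc3)c2n1` carries the core of compound 1 with one change, (amino in place of hydrogen on an aromatic carbon), and in this assay compound 2 gives 10000 nM. The step is an 8.5-fold higher number from compound 1 to compound 2 (0.93 log units; beyond the scatter), so the amino group weakens growth inhibition clearly here.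

Compound 3 `ClCc1ccccc1Cn1cnc2c(Cl)ncnc21` has the same atoms as compound 1 joined differently; the difference between the two cores is not broken down here. In this assay compound 3 gives 24000 nM, the highest number of the three, with compound 2 nearest and compound 1 furthest from it.

Compound 4 `Nc1nc(Cl)c2ncn(Cc3ccccc3CCl)c2n1` is not yet measured. It differs from compound 3 by amino in place of hydrogen on an aromatic carbon, and the place described for this change matches word for word the place described for the change from compound 1 to compound 2, so it is the same change made on the other core. The one precedent, an 8.5-fold higher number from compound 1 to compound 2 (0.93 log units; beyond the scatter), is the only basis for expectation; the two cores have not been shown to respond alike to any change, so the transfer is uncertain. Compound 4 is expected to follow the precedent in direction, giving a step of a 6.3-fold higher number from compound 3 to compound 4 (0.80 log units; beyond the scatter) in this assay. Compound 4 is therefore estimated at 150000 nM in this assay, within a range of 40000 nM to 500000 nM, with some chance that compound 4 exceeds the range of this assay and only a limit is reported.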

Compound 4, concentration for total growth inhibition: 38000 nM
The estimate for compound 4 lay 3.9-fold (0.60 log units) above the measured number; measured number below the stated range.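

In this assay, amino in place of hydrogen on an aromatic carbon gives a 1.6-fold higher number from compound 3 to compound 4 (0.20 log units; within the scatter), a step that stays within the usual scatter, so compound 4 and compound 3 cannot be told apart here. The change therefore does not carry over in size from the core of compound 1 to the core of compound 3, and the two steps have to be read as different: the same change on two cores in this assay, an 8.5-fold higher number (0.93 log units; beyond the scatter) from compound 1 to compound 2 and a 1.6-fold higher number (0.20 log units; within the scatter) from compound 3 to compound 4, 5.4-fold (0.73 log units) apart, beyond the scatter of two such steps. This rests on one pair for each core in a single cell assay, so it shows that the size of the step depends on the core in this series but does not show what in the two cores sets them apart, nor whether other changes would differ between them in the same way.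

Still open, as far as these compounds go, is whether a methylamino or hydroxyl group in the place taken by amino, on the aromatic carbon between two ring nitrogen atoms, would also give steps that differ between the two cores. Also open, from the compounds shown here alone, is whether the gap between the cores would persist with a methoxy group or a fluoro group in place of the chloro group.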